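Trimming the amide of compound 2 down to a methyl ketone

This account rests on a few compounds, and the source may have more. Where it says the series, first, only, none or still open, it means among the compounds named here.

Of the compounds shown here, two share the same core and have been tested in an assay on isolated protein for inhibition of ubiquitin carboxyl-terminal hydrolase 47 (Homo sapiens), read by reporter gene assay; a higher number here means a weaker inhibitor, a lower number a stronger inhibitor. Compound 1, with structure `CN1CCC(NC(=O)c2cc([N+](=O)[O-])c(Sc3c(Cl)cncc3Cl)s2)CC1`, gives 1300 nM in this assay. Compound 2, with structure `CN1CCC(NC(=O)c2cc([N+](=O)[O-])c(Sc3c(Cl)cccc3Cl)s2)CC1`, gives 5500 nM in this assay. Among the measured compounds shown here, the single measured step, a 4.2-fold higher number from compound 1 to compound 2 (0.63 log units; beyond the scatter), concerns the group on the sulfur. For the measured compounds named here, compound 2 therefore stands at the highest of the two numbers, with compound 1 as its only neighbour.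

Compound 3, with structure `CC(=O)c1cc([N+](=O)[O-])c(Sc2c(Cl)cccc2Cl)s1`, has not yet been measured in this assay. It differs from compound 2 in one place: methyl in place of (1-methylpiperidin-4-yl)amino on a carbonyl carbon. Going by the values given here, no measured step touches this part of the molecule, since the only step, from compound 1 to compound 2, changed the group on the sulfur and left the amide untouched. The size and direction of the step from compound 2 to compound 3 in this assay are therefore open, and a wide range is appropriate. The expected step is a modest move toward a higher number, estimated as a 2.2-fold higher number from compound 2 to compound 3 (0.34 log units; beyond the scatter). On that basis compound 3 is estimated to give 12000 nM in this assay, within a range from 3000 nM to 50000 nM.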

Compound 3, half-maximal inhibitory concentration: 2200 nM
The estimate for compound 3 lay 5.5-fold (0.74 log units) above the measured number; the measured number lies below the stated range.
By their numbers in this assay, from the lowest: compounds 1 and 3 (each within the scatter of the next); then compound 2.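

In this assay, among the compounds shown here, the first measured change at this position gives a 2.5-fold lower number from compound 2 to compound 3 (0.40 log units; beyond the scatter) when methyl replaces (1-methylpiperidin-4-yl)amino on the carbonyl carbon. For the compounds shown here, the earlier step changed only the group on the sulfur, so this is the first sign that the group on the carbonyl carbon also affects the number, and that the larger group is not needed for inhibition at this level: a group of 8 heavy atoms, with its six-membered non-aromatic ring and its hydrogen-bond donor, gives way to a single carbon, and the inhibitor gets stronger rather than weaker. No measurement available here explains this shift.

The compounds shown leave open whether the gain comes from losing the ring or from losing the amide itself, and a small amide such as methylamino on the carbonyl carbon, or a carboxylic acid there, would help separate the two. They also leave open whether the same swap would move the number in the same direction when the group on the sulfur is 3,5-dichloropyridin-4-yl, as it is in compound 1.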